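Shortening a benzyl to a phenyl on a guanidine-urea

The source may report more compounds than this note shows. Statements on the series, on what has been measured and on what is new or still open speak of the compounds shown alone.

Three compounds share a common core and are compared in a functional assay on HEK293T cells for agonist activity at histamine H2 receptor (Homo sapiens), read by beta-arrestin recruitment; a lower number here means a smaller maximal response, a higher number a larger maximal response. Compound 1 `Cc1nc(N)sc1CCCN/C(N)=N/C(=O)NC1CCCCC1` carries a cyclohexyl on the amide-type nitrogen and gives 0.43. Compound 2 `Cc1nc(N)sc1CCCN/C(N)=N/C(=O)NC(C)c1cccc(F)c1` gives 0.3. Compound 3 `Cc1nc(N)sc1CCCN/C(N)=N/C(=O)NCc1ccccc1` gives 0.33, a value lying between the other two and within the usual scatter of both; the single-step comparison a number 0.10 lower from compound 1 to compound 3 (within the scatter) shows that swapping cyclohexyl for benzyl did not move the response beyond the scatter.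

Compound 4 `Cc1nc(N)sc1CCCN/C(N)=N/C(=O)Nc1ccccc1` differs from compound 3 in one place: phenyl in place of benzyl on an amide-type nitrogen. Going by the values given here, no measured step covers exactly this change, and the three values gathered so far all sit in a narrow band, so there is no basis for expecting a shift beyond the scatter in this assay. The expected step a number 0.020 higher from compound 3 to compound 4 (within the scatter) is therefore estimated as small. Compound 4 is expected to give about 0.35, with a likely range from 0.22 to 0.5.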

Compound 4, intrinsic activity: the largest response reached, as a fraction of the reference agonist's: 0.25
Compound 4: middle estimate off by 0.10, on the high side; low and high end bracket the measured number.
By their numbers in this assay, from the lowest: compounds 4, 2, 3 and 1 (each within the scatter of the next, the first and the last beyond it).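

The step a number 0.080 lower from compound 3 to compound 4 (within the scatter) for phenyl in place of benzyl on the amide-type nitrogen shows that this shortening alone cannot be told apart from ordinary variation in this assay. The step a number 0.18 lower from compound 1 to compound 4 (beyond the scatter) for phenyl in place of cyclohexyl is the only step shown here that passes the scatter, so the group on this nitrogen can change the maximal response, though only modestly. Nothing available explains this difference.

On these data alone, whether a longer chain such as phenylethyl on this nitrogen, or an amine or a carboxylic acid on the phenyl ring, would change the response remains open. Compound 2 differs from compound 3 in more than one place, so the separate contributions of its added methyl and fluorine also remain unresolved.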